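Cytotoxicity notes: anilide ring swap from compound 1

A few compounds are considered here, and "the series" means these few. Any claim that something is new, unique, unknown or untested is made for them only; others in the source may bear on it.

In a toxicity assay on HepG2 cells (Homo sapiens) for inhibition, read by CellTiter-Glo, with a stated time of 48 h (a higher number here means a weaker inhibitor, a lower number a stronger inhibitor), compound 1 `COc1ccc2nc(C)cc(OCC(=O)Nc3cc(C)cc(C)c3)c2c1` gives 20000 nM. Compound 3 `COc1ccc2nc(C)cc(OC(C)C(=O)Nc3cc(C)cc(C)c3)c2c1` gives 39800 nM, which is a 2.0-fold higher number from compound 1 to compound 3 (0.30 log units; within the scatter). Compound 2 `Cc1cc(C)cc(NC(=O)COc2cc(C)nc3ccc(OC(F)(F)F)cc23)c1` reaches only the assay limit, > 100000 nM. The step of an at least 5.0-fold higher number from compound 1 to compound 2 (0.69 log units; beyond the scatter) rests on (the limit of > 100000 nM in this assay, at which 1 of the 3 values shown sits). Compound 4 `COc1ccc2nc(C)cc(OCC(=O)Nc3cc(C)ccc3OC)c2c1` differs from compound 1 by 2-methoxy-5-methylphenyl in place of 3,5-dimethylphenyl on an amide-type nitrogen. Going by the values given here, neither measured step touches the amide-side ring: the step to compound 3 alters the chain carbon, the step to compound 2 the aryl ether, so no measured step bears directly on this change. The expectation for compound 4 in this assay is therefore a step of about a 1.5-fold higher number from compound 1 to compound 4 (0.18 log units; within the scatter), with no clear direction beyond the scatter. Compound 4 is estimated at 30000 nM, in the range 10000 nM to 100000 nM.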

Compound 4, half-maximal inhibitory concentration: > 100000 nM
Compound 4 gave a limit, no number; the forecaster's own chance of this, stated with the estimate: 25%; middle value at least 3.3-fold (0.52 log units) from the limit.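

In this assay, the amide-side ring proves to be a position where a change shows beyond the scatter: 2-methoxy-5-methylphenyl in place of 3,5-dimethylphenyl on an amide-type nitrogen gives an at least 5.0-fold higher number from compound 1 to compound 4 (0.69 log units; beyond the scatter). The earlier steps shown here touched only the chain carbon and the aryl ether, so they gave no reading of this ring. The value of compound 4 is a limit, so this step is bounded on one side only: the limit of > 100000 nM in this assay, at which 2 of the 4 values shown sit.

Open, from the compounds shown here alone, is whether the methoxy of the entering group alone carries the step, and how an amine or a carboxylic acid on this ring would read in this assay.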